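This account rests on a few compounds, and the source may have more. Where it says the series, first, only, none or still open, it means among the compounds named here.

Compound 1 `COc1cc2ncnc(Nc3ccc(F)c(Cl)c3)c2cc1OCCCCC(=O)Nc1ccc(S(N)(=O)=O)cc1` gives 15500 nM in a functional assay on A549 cells (Homo sapiens) for antiproliferative activity, read by MTT assay, with a stated time of 72 h; on this read-out lower numbers stand for stronger inhibition and higher numbers for weaker inhibition.
Compound 2 `COc1cc2ncnc(Nc3ccc(F)cc3)c2cc1OCCCCC(=O)Nc1ccc(S(N)(=O)=O)cc1` gives only a limit of this assay, > 40000 nM, and not a number.
Compound 3 `NS(=O)(=O)c1ccc(NC(=S)Nc2ccc3ncnc(Nc4cccc(C(F)(F)F)c4)c3c2)cc1` gives 10100 nM in this assay.

Compounds 1 and 2 share one core and differ in a single place: chloro in place of hydrogen on an aromatic carbon. That change gives an at least 2.5-fold lower number from compound 2 to compound 1 (0.41 log units; beyond the scatter). The size of this step is known only as a lower bound because of the limit of > 40000 nM in this assay, at which 1 of the 3 values shown sits.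

Compound 3 is built on a different core, and the difference between the two cores is not broken down here. Its value and that of compound 1 lie within the scatter of each other, so nothing separates them.

Compound 4 `NS(=O)(=O)c1ccc(NC(=S)Nc2ccc3ncnc(Nc4ccc(Cl)c(C(F)(F)F)c4)c3c2)cc1` has not yet been measured. It differs from compound 3 in one place: chloro in place of hydrogen on an aromatic carbon. This is the same kind of change as from compound 2 to compound 1, but not the same: in compound 1 the chloro sits ortho to a fluoro group and meta to a large group, while in compound 4 it sits ortho to a trifluoromethyl group and para to a large group.

Within the data shown here, a step of similar direction is expected, a 2.2-fold lower number from compound 3 to compound 4 (0.35 log units; beyond the scatter), resting on the single measured step from compound 2 to compound 1 and on the value of compound 3, 10100 nM. Compound 4 is therefore estimated at 4500 nM, with a range from 1500 nM to 14000 nM.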

Compound 4, half-maximal inhibitory concentration: 4500 nM
Estimate against measurement, compound 4: no gap at the digits printed; the range from low to high includes it.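

On both cores shown, chloro in place of hydrogen on an aromatic carbon goes with a lower number in this assay, and the new pair gives a 2.2-fold lower number from compound 3 to compound 4 (0.35 log units; beyond the scatter). Set side by side, the two steps compare as follows: the same change on two cores in this assay, an at least 2.5-fold lower number (0.41 log units; beyond the scatter) from compound 2 to compound 1 and a 2.2-fold lower number (0.35 log units; beyond the scatter) from compound 3 to compound 4; the limit leaves it open whether they differ. This is a shared direction in two pairs of compounds and not a rule for the whole series, and it does not fix how large the change is on the core of compound 1, because that step rests on a limit and not on a number: the limit of > 40000 nM in this assay, at which 1 of the 4 values shown sits.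

The compounds shown leave open whether another group on that same aromatic carbon, such as a bromo, a methyl or a methoxy, would give a step like the one seen with chloro. They also leave open whether the chloro would lower the number in the same way on a third core, or when the group it joins on the ring is something other than a fluoro or a trifluoromethyl group, such as a nitrile.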